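Swapping a ring for an ethoxy group on a pyridine

The source may hold more compounds than are shown below. What is called first, only, known or untested is meant among the compounds shown, and "the series" means these compounds.

Measured so far:
compound 1, `CC(C(=O)NCc1ccc(C(C)(C)C)nc1N1CCCC1)c1ccc(NS(C)(=O)=O)c(F)c1`: 1.2 nM
compound 2, `CC(C(=O)NCc1ccc(C(C)(C)C)nc1N1CCC(Cc2ccccc2)CC1)c1ccc(NS(C)(=O)=O)c(F)c1`: 0.3 nM

Both compounds were tested in an assay on cells for antagonist activity at transient receptor potential cation channel subfamily V member 1 (Homo sapiens), read by FLIPR and calcium flux, with a stated time of 6 min; on this read-out lower numbers stand for stronger inhibition and higher numbers for weaker inhibition. Compound 1 gives 1.2 nM, which is the higher of the two numbers; compound 2 gives 0.3 nM, a lower number that lies beyond the usual scatter of the method. Among the measured compounds shown here, the two differ in the saturated ring that sits on the shared core, but no step between them has been worked out here, so the two values are simply reported side by side.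

Compound 3, `CCOc1nc(C(C)(C)C)ccc1CNC(=O)C(C)c1ccc(NS(C)(=O)=O)c(F)c1`, has not yet been measured. It differs from compound 1 in one place: ethoxy in place of pyrrolidin-1-yl on an aromatic carbon. The five-membered ring is gone and a short, open chain bearing a single hydrogen-bond acceptor takes its place. For the measured compounds named here, nothing among the measured compounds shows directly what such a change does, so the expectation rests on compound 1 alone. A modest loss is expected, a step of a 3.3-fold higher number from compound 1 to compound 3 (0.52 log units; beyond the scatter) in this assay, in the direction of weaker inhibition. Compound 3 is therefore estimated at 4 nM, with a plausible range from 1 nM to 20 nM.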

Compound 3, inhibition constant: 14.8 nM
Beside the measured number, compound 3's estimate is 3.7-fold (0.57 log units) below it; measured number inside the range.
By their numbers in this assay, from the lowest: compound 2; then compound 1; then compound 3.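

In this assay, ethoxy in place of pyrrolidin-1-yl gives a 12-fold higher number from compound 1 to compound 3 (1.09 log units; beyond the scatter) and so marks a large move towards weaker inhibition. Among the compounds shown here, this is the first direct reading at this position, on an aromatic carbon next to the ring nitrogen, and it shows that inhibition depends strongly on which group sits there. The two groups match in their counts of hydrogen-bond donors and acceptors, so those counts alone do not separate them, and nothing measured here explains the loss.

From the compounds shown here alone, the change alters several things at once: the ring goes, oxygen replaces nitrogen as the atom on the aromatic carbon, and the group drops from 5 heavy atoms to 3, so which of these matters most remains open. An open-chain amine such as diethylamino would keep the nitrogen without the ring, while a longer chain such as butoxy would keep the oxygen with more heavy atoms, and together these would help pull the three changes apart.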